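The compounds below may be only part of what the source reports. "The series", "measured", "known", "first", "only" and "open" are said of these compounds alone.

Going by the values given here, compound 2 `O=C(Nc1ccccc1[N+](=O)[O-])N[C@H]1CC[C@H](Oc2ccc(F)cc2)CC1` gives the lowest number so far: in a functional assay on CRL2813 cells (Homo sapiens) for cytotoxicity, read by sulforhodamine B assay, with a stated time of 5 days (a lower number here means a stronger inhibitor, a higher number a weaker inhibitor), compound 2 gives 3500 nM, while compound 1 `O=C(Nc1ccc(F)cc1)N[C@H]1CC[C@H](Oc2ccc(F)cc2)CC1` gives 20000 nM. Compound 3 `O=C(Nc1ccc(Cl)cc1)N[C@H]1CC[C@H](Oc2ccc(F)cc2)CC1` carries 4-chlorophenyl in place of 2-nitrophenyl on an amide-type nitrogen. Among the compounds with values here, the only step that bears on this is a 5.7-fold lower number from compound 1 to compound 2 (0.76 log units; beyond the scatter), and compound 3 reverts to a simple halogen-bearing ring much like that of compound 1. The change from compound 2 to compound 3 is therefore expected to be a step to a higher number, roughly a 3.4-fold higher number from compound 2 to compound 3 (0.54 log units; beyond the scatter), undoing most of that gain. Compound 3 is estimated at 12000 nM, within a range of 4000 nM to 40000 nM.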

Compound 3, half-maximal inhibitory concentration: > 20000 nM
Compound 3 gave a limit, no number; the forecaster's own chance of this, stated with the estimate: 15%; middle value at least 1.6-fold (0.22 log units) from the limit.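

In this assay compound 3 gives > 20000 nM, which is a limit of the assay and not a number. The step is an at least 5.7-fold higher number from compound 2 to compound 3 (0.75 log units; beyond the scatter), so at this amide-type nitrogen the lower number of compound 2 is shared by neither halogen-bearing ring, 4-fluorophenyl or 4-chlorophenyl. The step from fluoro to chloro is a number no lower from compound 1 to compound 3 (the limit leaves the size open) and its size cannot be read. On these data alone, whether the nitro group itself or its place on the ring matters stays open, and so does how 4-nitrophenyl or 2-chlorophenyl would behave here.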